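Chloro Substitution and Tolerated Concentration in Three Measured Compounds

A few compounds are considered here, and "the series" means these few. Any claim that something is new, unique, unknown or untested is made for them only; others in the source may bear on it.

Compound 1 `O[C@@H]1Cc2ccccc2N[C@H](c2ccccc2)C1` gives > 300000 nM.
Compound 2 `O[C@@H]1Cc2cc(F)ccc2N[C@H](c2ccccc2)C1` gives > 300000 nM.
Compound 3 `O[C@@H]1Cc2cc(F)ccc2N[C@H](c2ccc(Cl)cc2)C1` gives 100000 nM.

In an ADME assay on THP-1 cells (Homo sapiens) for cytotoxicity, read by MTT assay, with a stated time of 72 h (a higher number here means that more compound is tolerated, a lower number that less compound is tolerated), the value of compound 1 is a limit of the assay, not a number. The value of compound 2 is likewise a limit. The step that the two limits leave unreadable from compound 1 to compound 2 cannot be read because of the limit of > 300000 nM in this assay, at which 2 of the 3 values shown sit. Compound 3, however, gives a number, and the step of an at least 3.0-fold lower number from compound 2 to compound 3 (0.47 log units; beyond the scatter) rests on the change (chloro in place of hydrogen on an aromatic carbon).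

Compound 4 `O[C@@H]1Cc2ccccc2N[C@H](c2ccccc2Cl)C1` is not yet measured. It differs from compound 1 by chloro in place of hydrogen on an aromatic carbon. The cores of compound 1 and compound 2 differ by hydrogen in place of fluoro on an aromatic carbon. The two chloro changes are the same kind of change but not the same: in compound 3 the chloro sits para to a large group, in compound 4 ortho to a large group.

From compound 1 to compound 4, a step of an at least 3.0-fold lower number from compound 1 to compound 4 (0.47 log units; beyond the scatter) is expected in this assay, resting on the step of an at least 3.0-fold lower number from compound 2 to compound 3 (0.47 log units; beyond the scatter) seen with the same kind of change. Compound 4 is estimated at 100000 nM, between 30000 nM and 300000 nM.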

Compound 4, half-maximal cytotoxic concentration: > 300000 nM
Compound 4 was reported as a limit; the forecaster's own chance of this, stated with the estimate: 35%; middle value at least 3.0-fold (0.47 log units) from the limit.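

No new step can be read from compound 1 to compound 4 in this assay, because both values are limits: the limit of > 300000 nM in this assay, at which 3 of the 4 values shown sit. The compounds shown leave open how far chloro ortho to a large group changes the tolerated concentration.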